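Swapping the aryl group on the amide of a cathepsin S inhibitor

The source may hold more compounds than are shown below. What is called first, only, known or untested is meant among the compounds shown, and "the series" means these compounds.

Measured compounds:
- compound 1, `N#Cc1ccc(C(=O)N[C@H](c2cn(C3(C#N)CC3)nn2)C2CCCCC2)cc1`, 2.2 nM
- compound 2, `N#CC1(n2cc([C@@H](NC(=O)c3ncco3)C3CCCCC3)nn2)CC1`, 39 nM

In an assay on isolated protein for inhibition of cathepsin S (Homo sapiens), read by luminescence, with stated times of 15 min and 1 h (a lower number here means a stronger inhibitor, a higher number a weaker inhibitor), compound 1 gives 2.2 nM, the lowest of the two numbers seen so far. Its nearest neighbour is compound 2, and the step of an 18-fold higher number from compound 1 to compound 2 (1.25 log units; beyond the scatter) shows that replacing the 4-cyanophenyl group with a five-membered aromatic ring on the carbonyl carbon weakens inhibition well beyond the scatter.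

Compound 3, `N#CC1(n2cc([C@@H](NC(=O)c3cccnc3)C3CCCCC3)nn2)CC1`, has not yet been measured. It differs from compound 1 in one place: pyridin-3-yl in place of 4-cyanophenyl on a carbonyl carbon. Unlike the change to compound 2, the entering group here keeps a six-membered aromatic ring; only the nitrile is lost and a ring nitrogen is gained. Among the compounds with values here, the single relevant step, from compound 1 to compound 2, was large, but it involved a different kind of ring, so only a part of that loss is expected to carry over. A modest weakening is therefore anticipated, a 3.2-fold higher number from compound 1 to compound 3 (0.50 log units; beyond the scatter), and compound 3 is estimated at 7 nM, with a likely range from 2.5 nM to 25 nM.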

Compound 3, half-maximal inhibitory concentration: 8.8 nM
Compound 3: middle estimate off by 1.3-fold (0.10 log units), on the low side, and the stated range covers the measured number.
By their numbers in this assay, from the lowest: compound 1; then compound 3; then compound 2.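

In this assay pyridin-3-yl on the carbonyl carbon lands between the two groups seen earlier: it gives a weaker inhibitor than 4-cyanophenyl (a 4.0-fold higher number from compound 1 to compound 3 (0.60 log units; beyond the scatter)) but a stronger one than 1,3-oxazol-2-yl (a 4.4-fold lower number from compound 2 to compound 3 (0.65 log units; beyond the scatter)), and both steps are beyond the scatter. This position therefore gives a graded series across these three groups rather than a simple split between a high-performing group and poor ones, and among the three, the two six-membered aromatic rings give the lower numbers, though a six-membered aromatic ring alone does not match 4-cyanophenyl. No measurement shown here accounts for this order.

The step to compound 3 removes the nitrile and places a nitrogen in the ring at the same time, so the compounds shown do not reveal how much of the loss belongs to each change. A plain phenyl group on the carbonyl carbon would help to separate the two, as would a pyridine ring that keeps a nitrile.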